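Nitro to Amino on the Aryl Carbonyl Arm

A few compounds are considered here, and "the series" means these few. Any claim that something is new, unique, unknown or untested is made for them only; others in the source may bear on it.

Of the compounds shown here, three sharing one core have been measured in an assay on isolated protein for inhibition of Rho-associated protein kinase 1 (Homo sapiens), read by scintillation counting, radiometric assay and 33P incorporation, with a stated time of 40 min, in the presence of a further agent that is not named here; a higher number here means a weaker inhibitor, a lower number a stronger inhibitor. Compound 1 `CC(=O)Nc1cccc(NC(=O)COc2ccc3c(=O)ccoc3c2)c1` gives 2500 nM, compound 2 `CCOc1ccc(C(=O)Nc2cccc(NC(=O)COc3ccc4c(=O)ccoc4c3)c2)cc1` gives 17 nM, and compound 3 `O=C(COc1ccc2c(=O)ccoc2c1)Nc1cccc(NC(=O)c2cccc([N+](=O)[O-])c2)c1` gives 528 nM. Compound 3 thus stands second highest of the three: it is a 31-fold higher number from compound 2 to compound 3 (1.49 log units; beyond the scatter), while a 4.7-fold lower number from compound 1 to compound 3 (0.68 log units; beyond the scatter). Compound 4 `Nc1cccc(C(=O)Nc2cccc(NC(=O)COc3ccc4c(=O)ccoc4c3)c2)c1` differs from compound 3 in one place: amino in place of nitro on an aromatic carbon, on an aromatic carbon of a six-membered aromatic ring of carbon only, meta to a large group.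

Among the measured compounds shown here, no measured step exchanges nitro for amino, so the bearing of the known steps is indirect. What they show is that the group on the carbonyl carbon governs the read-out strongly: a 150-fold lower number from compound 1 to compound 2 (2.17 log units; beyond the scatter) and a 31-fold higher number from compound 2 to compound 3 (1.49 log units; beyond the scatter), both beyond the scatter. A change within that aryl group is therefore expected to move the number beyond the scatter, and the estimate leans toward a lower number. Compound 4 is estimated at 200 nM, within 50 nM to 800 nM, which would mean an expected 2.6-fold lower number from compound 3 to compound 4 (0.42 log units; beyond the scatter).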

Compound 4, half-maximal inhibitory concentration: 670 nM
Beside the measured number, compound 4's estimate is 3.4-fold (0.53 log units) below it; low and high end bracket the measured number.
By their numbers in this assay, from the lowest: compound 2; then compounds 3 and 4 (each within the scatter of the next); then compound 1.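

In this assay, amino in place of nitro on this aromatic carbon, meta to a large group, gives a 1.3-fold higher number from compound 3 to compound 4 (0.10 log units; within the scatter), so the two groups cannot be told apart at this place even though they differ in size and in hydrogen-bond donors. The 3-aminophenyl group stays well short of 4-ethoxyphenyl, with a 39-fold higher number from compound 2 to compound 4 (1.60 log units; beyond the scatter), and holds only a modest margin over methyl, with a 3.7-fold lower number from compound 1 to compound 4 (0.57 log units; beyond the scatter), much as 3-nitrophenyl did. Nothing measured here speaks to the reason for this result.

The compounds shown leave open whether other groups at this place, such as a methoxy group or a carboxylic acid, would also stay level with nitro and amino. They also leave open whether ethoxy itself accounts for the standing of compound 2, since a plain phenyl on the carbonyl carbon is not among them.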